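The source may report more compounds than this note shows. Statements on the series, on what has been measured and on what is new or still open speak of the compounds shown alone.

Measured so far, in a functional assay on HT-29 cells (Homo sapiens) for cytotoxicity, read by MTT assay, with a stated time of 24 h, tested at 0.64 ug/mL; on this read-out higher numbers stand for a stronger effect at the one concentration tested and lower numbers for a weaker effect:

- Compound 1 `Cn1c(-c2ccc(NC(=O)CSc3nc4ccccc4o3)cc2)nc(-c2ccccc2)c1-c1ccccc1`: compound 1 gives 24.8%
- Compound 2 `Cn1c(-c2ccc(NC(=O)CSc3nc4cc(Cl)ccc4o3)cc2)nc(-c2ccccc2)c1-c1ccccc1`: compound 2 gives 11.9%
- Compound 3 `Cn1cnnc1SCC(=O)Nc1ccc(-c2nc(-c3ccccc3)c(-c3ccccc3)n2C)cc1`: compound 3 gives 32%

All three share one core and differ only in the group attached to the sulfur of the side chain. Compound 2 stands lowest of the three numbers. Its nearest neighbour is compound 1, and the step of a number 12.9 percentage points lower from compound 1 to compound 2 (beyond the scatter) marks the gap; the furthest is compound 3, reached by the step of a number 20.1 percentage points higher from compound 2 to compound 3 (beyond the scatter).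

The piece now moves from compound 2 to compound 4 `Cn1c(-c2ccc(NC(=O)CSC3=NCCS3)cc2)nc(-c2ccccc2)c1-c1ccccc1`, which is not yet measured. The change is a group of 5 heavy atoms (3 carbon, 1 nitrogen, 1 sulfur; one five-membered non-aromatic ring with 2 hetero atoms) in place of a group of 10 heavy atoms (7 carbon, 1 nitrogen, 1 oxygen, 1 chlorine; one five-membered aromatic ring with 2 hetero atoms, one six-membered aromatic ring of carbon only), on a sulfur. The 5-chloro-1,3-benzoxazol-2-yl leaves, and a smaller five-membered non-aromatic ring with 2 hetero atoms enters on the sulfur.

Within the data shown here, two measured steps bear on this. Taking away the chloro alone gave the step of a number 12.9 percentage points lower from compound 1 to compound 2 (beyond the scatter) read in reverse, a modest rise. Trading the whole chlorinated bicyclic group for a small 4-methyl-4H-1,2,4-triazol-3-yl gave a number 20.1 percentage points higher from compound 2 to compound 3 (beyond the scatter), a larger rise. Among the measured compounds shown here, both point the same way: a smaller group on the sulfur has so far gone with a higher read-out, though only three compounds support this. A rise beyond the scatter is therefore expected for compound 4, roughly the size seen for compound 3.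

Compound 4 is expected to give about 26%, likely between 12% and 40%. That estimate corresponds to an expected step of a number 14.1 percentage points higher from compound 2 to compound 4 (beyond the scatter).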

Compound 4, a percentage reported as activity, at one concentration (the size of the read-out at that concentration, not a potency): 16.8%
The estimate for compound 4 lay 9.2 percentage points above the measured number; measured number inside the range.
By their numbers in this assay, from the lowest: compounds 2, 4, 1 and 3 (each within the scatter of the next, the first and the last beyond it).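

In this assay, a smaller group on the sulfur no longer goes with a clearly higher number: with a group of 5 heavy atoms in the place of larger ones, the result is a number 4.9 percentage points higher from compound 2 to compound 4 (within the scatter) and a number 8 percentage points lower from compound 1 to compound 4 (within the scatter), so compound 4 cannot be told apart from either benzoxazole compound. The clear gap appears instead between two groups of similar size, the 4-methyl-4H-1,2,4-triazol-3-yl and the non-aromatic five-membered ring, with a number 15.2 percentage points lower from compound 3 to compound 4 (beyond the scatter), so compound 3 goes against any rule based on size alone and size by itself does not account for its number. Nothing measured here explains the gap between these two groups.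

On these data alone, it remains open whether the number of compound 3 goes with its aromatic ring, its three ring nitrogens or its methyl group, as a single triazole compound cannot separate these features. Also open, as far as these compounds go, is how a group without a ring on the sulfur, such as an ethyl chain, a longer chain ending in an amine or one ending in a carboxylic acid, would behave at this one concentration.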